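This account rests on a few compounds, and the source may have more. Where it says the series, first, only, none or still open, it means among the compounds named here.

Measured so far:
- compound 1 `Nc1ncnc2c1c(Oc1cc(C(F)(F)F)ccn1)nn2[C@H]1C[C@H](F)C1`: 0.883 h
- compound 2 `Nc1ncnc2c1c(Oc1cc(C(F)(F)F)ccn1)nn2C1CCC(O)C1`: 0.3 h

In an ADME assay on microsomes from liver (Mus musculus) for metabolic stability, read by LC-MS, using NADPH, with a stated time of 10 min, tested at 10 uM (a higher number here means that the compound lasts longer, a lower number that the compound disappears faster), compound 2 has the lower of the two numbers, at 0.3 h. The next structure to test is compound 3 `Nc1ncnc2c1c(Oc1cc(C(F)(F)F)ccn1)nn2C1CCC1`, which carries cyclobutyl in place of 3-hydroxycyclopentyl on an aromatic nitrogen.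

Going by the values given here, only one measured step bears on this change: a 2.9-fold lower number from compound 1 to compound 2 (0.47 log units; beyond the scatter). It is modest but beyond the scatter, and it introduced the same 3-hydroxycyclopentyl that now leaves. Removing that group should therefore give a rise in half-life, of similar or somewhat smaller size, since the incoming cyclobutyl is not identical to the 3-fluorocyclobutyl that left. A single step is a thin guide, so the uncertainty is wide.

The expected change is a 2.0-fold higher number from compound 2 to compound 3 (0.30 log units; within the scatter). The estimate for compound 3 is 0.6 h, with an expected range of 0.28 h to 1.2 h.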

Compound 3, half-life: 0.128 h
Compound 3: the middle estimate sits 4.7-fold (0.67 log units) above what was measured; measured number below the stated range.
By their numbers in this assay, from the lowest: compound 3; then compound 2; then compound 1.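

In this assay, the unsubstituted cyclobutyl sits lowest of the three, with a 2.3-fold lower number from compound 2 to compound 3 (0.37 log units; beyond the scatter), so the 3-hydroxycyclopentyl that looked poor beside 3-fluorocyclobutyl still outlasts the bare four-membered ring. Hydrogen in place of fluoro on the saturated ring carbon gives the larger of the two new steps, a 6.9-fold lower number from compound 1 to compound 3 (0.84 log units; beyond the scatter), which shows that a single substituent on the cyclobutyl ring can move this number strongly. Nothing measured here explains why the numbers fall in this order.

Still open, going by these compounds, is whether ring size or the substituent matters more, since the hydroxyl and the fluoro sit on different rings. A cyclobutyl ring bearing a hydroxyl, a methoxy group or an amine would help separate these two changes.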